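Quinoline amides on colon cancer cells: one repeated swap

The source may hold more compounds than are shown below. What is called first, only, known or untested is meant among the compounds shown, and "the series" means these compounds.

In a functional assay on HT-29 cells (Homo sapiens) for cytotoxicity, read by MTT assay, with a stated time of 72 h (on this read-out higher numbers stand for weaker inhibition and lower numbers for stronger inhibition), compound 1 `COc1cccc(-c2cc(C(=O)Nc3ccc(Oc4ccnc5cc(OCCCN6CCCC6)c(OC)cc45)c(F)c3)c3ccccc3n2)c1` gives 1020 nM and compound 2 `COc1cc2c(Oc3ccc(NC(=O)c4cc(-c5ccc(C)cc5)nc5ccccc45)cc3F)ccnc2cc1OCCCN1CCCC1` gives 850 nM. Their structures differ in one place, (4-methylphenyl in place of 3-methoxyphenyl on an aromatic carbon), and the step was a 1.2-fold lower number from compound 1 to compound 2 (0.08 log units; within the scatter). Compound 3 `COc1cccc(-c2cc(C(=O)Nc3ccc(Oc4ccnc5cc(OCCCN6CCC(C)CC6)c(OC)cc45)c(F)c3)c3cc(F)ccc3n2)c1` gives 1210 nM in this assay; how its core differs from the core of compound 1 is not broken down here. Compound 4 `COc1cc2c(Oc3ccc(NC(=O)c4cc(-c5ccc(C)cc5)nc5ccc(F)cc45)cc3F)ccnc2cc1OCCCN1CCC(C)CC1` carries the same change against compound 3, namely (4-methylphenyl in place of 3-methoxyphenyl on an aromatic carbon), at a place described in the same words as for compound 1 and compound 2. Because the measured step of a 1.2-fold lower number from compound 1 to compound 2 (0.08 log units; within the scatter) stayed within the scatter, the step from compound 3 to compound 4 in this assay is expected to be similar, a 1.2-fold lower number from compound 3 to compound 4 (0.08 log units; within the scatter). Compound 4 is therefore estimated at 1000 nM in this assay, with a range from 500 nM to 2000 nM.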

Compound 4, half-maximal inhibitory concentration: 420 nM
Beside the measured number, compound 4's estimate is 2.4-fold (0.38 log units) above it; measured number outside the range, below it.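

The new step on the core of compound 3 is a 2.9-fold lower number from compound 3 to compound 4 (0.46 log units; beyond the scatter), which lies beyond the scatter, whereas a 1.2-fold lower number from compound 1 to compound 2 (0.08 log units; within the scatter) does not. Set side by side, however, the two steps do not separate: the same change on two cores in this assay, a 1.2-fold lower number (0.08 log units; within the scatter) from compound 1 to compound 2 and a 2.9-fold lower number (0.46 log units; beyond the scatter) from compound 3 to compound 4, 2.4-fold (0.38 log units) apart, within the scatter of two such steps. This gives no sign that the core alters the effect of 4-methylphenyl in place of 3-methoxyphenyl, but two pairs do not show that the step is the same on both cores, or that it would carry to any other core.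

The compounds shown leave open how a plain phenyl or a 4-chlorophenyl would behave in the same place on either core. They also leave open which of the differences between the two cores, if any, bears on the size of the step.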